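A few compounds are considered here, and "the series" means these few. Any claim that something is new, unique, unknown or untested is made for them only; others in the source may bear on it.

Working notes on the series. Compound 1 `CN(C)CCNc1ccnc2cc(OCc3ccc(F)cc3)ccc12`, compound 2 `CN(C)CCCNc1ccnc2cc(OCc3ccc(F)cc3)ccc12` and compound 3 `CCOc1ccc2c(NCCN(C)C)ccnc2c1` share one core; compound 4 `CCOc1ccc2c(NCCCN(C)C)ccnc2c1` is the next member and has not yet been measured. In a functional assay on HepG2 cells (Homo sapiens) for cytotoxicity, read by MTT assay, with a stated time of 48 h (on this read-out higher numbers stand for weaker inhibition and lower numbers for stronger inhibition), compound 1 gives 790 nM, compound 2 gives 1570 nM and compound 3 gives 5680 nM. Compound 3 thus shows the highest number of the three; against compound 1 the step is a 7.2-fold higher number from compound 1 to compound 3 (0.86 log units; beyond the scatter), and the number for compound 2 lies between those two values. The change from compound 3 to compound 4 is (dimethylamino)methyl in place of dimethylamino on a saturated chain carbon, two bonds along the chain from a nitrogen on an aromatic ring. The same exchange has been made once before in this set, on the 4-fluorophenyl-bearing pair, where it read a 2.0-fold higher number from compound 1 to compound 2 (0.30 log units; within the scatter). Within the data shown here, that single precedent points to a small rise in the number, if any; nothing among the measured compounds suggests a different outcome when the same exchange is made on the core of compound 3. For compound 4 in this assay a step of about a 1.9-fold higher number from compound 3 to compound 4 (0.29 log units; within the scatter) is therefore expected, upward, with a fair chance that it stays within the scatter. Compound 4 is estimated at 11000 nM, with a range from 5000 nM to 25000 nM.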

Compound 4, half-maximal inhibitory concentration: 5860 nM
Compound 4: middle estimate off by 1.9-fold (0.27 log units), on the high side; the range from low to high includes it.
By their numbers in this assay, from the lowest: compounds 1 and 2 (each within the scatter of the next); then compounds 3 and 4 (each within the scatter of the next).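

In this assay, (dimethylamino)methyl in place of dimethylamino on a saturated chain carbon, two bonds along the chain from a nitrogen on an aromatic ring, now has a second reading on a second core, a 1.0-fold higher number from compound 3 to compound 4 (0.01 log units; within the scatter), so this exchange stays within the scatter on both cores, and the two readings agree: the same change on two cores in this assay, a 2.0-fold higher number (0.30 log units; within the scatter) from compound 1 to compound 2 and a 1.0-fold higher number (0.01 log units; within the scatter) from compound 3 to compound 4, 1.9-fold (0.28 log units) apart, within the scatter of two such steps.
The other exchange, methyl in place of 4-fluorophenyl on a saturated chain carbon bound to an oxygen on an aromatic ring, now also has a second reading, a 3.7-fold higher number from compound 2 to compound 4 (0.57 log units; beyond the scatter), so it raises the number beyond the scatter with either 2-(dimethylamino)ethyl or 3-(dimethylamino)propyl on the nitrogen, and the two steps agree: the same change on two cores in this assay, a 7.2-fold higher number (0.86 log units; beyond the scatter) from compound 1 to compound 3 and a 3.7-fold higher number (0.57 log units; beyond the scatter) from compound 2 to compound 4, 1.9-fold (0.28 log units) apart, within the scatter of two such steps.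
Across these four compounds, only the steps of this second exchange lie beyond the scatter.

Open, going by these compounds, is whether a longer chain such as 4-(dimethylamino)butyl, or a morpholine in place of the dimethylamino end, would also leave the number within the scatter on these cores. Also open, on these data alone, is where a plain phenyl in place of 4-fluorophenyl would fall, so the part played by the fluorine in the step to methyl cannot yet be separated from that of the ring.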